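The compounds below may be only part of what the source reports. "The series", "measured", "known", "first", "only" and "open" are said of these compounds alone.

Measured so far:
compound 1 `Cc1ccnc(NC(c2ccc3cccnc3c2O)c2c(F)cccc2Cl)c1` — > 40000 nM
compound 2 `Oc1ccc2nccnc2c1C(c1ccc(F)cc1)N1CCCCC1` — > 100000 nM

In an assay for inhibition of protein disulfide-isomerase (Homo sapiens), with a stated time of 1 h (on this read-out lower numbers stand for stronger inhibition and higher numbers for weaker inhibition), compound 1 gives > 40000 nM, which is a limit of the assay and not a number, as the limit of > 40000 nM in this assay, at which 1 of the 2 values shown sits, records. Compound 2 also reaches only a limit, > 100000 nM, as the limit of > 100000 nM in this assay, at which 1 of the 2 values shown sits, records. Compound 1 therefore stands at a limit, and the two values shown allow no ordering. Compound 3 `Cc1ccnc(NC(c2ccc3cccnc3c2O)c2c(Cl)cccc2Cl)c1` differs from compound 1 by chloro in place of fluoro on an aromatic carbon. Going by the values given here, no measured step covers this pair. In this assay no change beyond the scatter is expected, the expected step being a step that the limit leaves unreadable from compound 1 to compound 3. Compound 3 is estimated at 50000 nM, within 15000 nM to 200000 nM.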

Compound 3, half-maximal inhibitory concentration: > 40000 nM
Compound 3: a limit, no number (the forecaster's own chance of this, stated with the estimate: 80%); the middle value does not contradict the limit.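

No step can be read from compound 1 to compound 3 in this assay, as both stand at the same limit: the limit of > 40000 nM in this assay, at which 2 of the 3 values shown sit.

The compounds shown give no number, leaving open whether chloro in place of fluoro changes inhibition at all.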